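The compounds below may be only part of what the source reports. "The series", "measured", "known", "first", "only" and "open" are said of these compounds alone.

Going by the values given here, compound 1 `Cc1ccccc1C(=O)NCc1ccc(CNS(=O)(=O)c2ccc(Cl)cc2)cc1` holds the lowest of the three numbers measured so far in an assay on MDA-MB-231 cells for displacement of a labelled ligand from C-X-C chemokine receptor type 4 (Homo sapiens), read by fluorescence and microscopy, with stated times of 10 min and 30 min; on this read-out higher numbers stand for an effect only at larger amounts of compound and lower numbers for an effect already at smaller amounts: compound 1 gives 1 nM. Compound 2 `Cc1ccccc1C(=O)NCc1ccc(CNS(=O)(=O)c2ccccc2C)cc1` gives 10 nM, and compound 3 `Cc1cccc(S(=O)(=O)NCc2ccc(CNC(=O)c3ccccc3C)cc2)c1` gives 1000 nM. All three measured steps concern the group on the sulfonyl sulfur: a 10-fold higher number from compound 1 to compound 2 (1.00 log units; beyond the scatter), a 1000-fold higher number from compound 1 to compound 3 (3.00 log units; beyond the scatter) and a 100-fold higher number from compound 2 to compound 3 (2.00 log units; beyond the scatter). Every one of these is beyond the scatter, so the read-out responds strongly to a change of a single aryl group at that end of the molecule, while the 2-methylphenyl on the carbonyl carbon stays the same in compounds 1, 2 and 3.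

Compound 4 `O=C(NCc1ccc(CNS(=O)(=O)c2ccc(Cl)cc2)cc1)c1cccnc1` keeps the 4-chlorophenyl on the sulfonyl sulfur of compound 1 and changes the other end instead: pyridin-3-yl in place of 2-methylphenyl on a carbonyl carbon. Among the compounds with values here, no measured step alters the group on the carbonyl carbon, so none bears directly on this change; the three steps only show how much a single aryl swap can move the number. Since compound 1 already sits at the lowest number seen, a move toward higher numbers is more likely than a further drop. Compound 4 is therefore expected to give 10 nM, within a range from 1 nM to 100 nM, which would mean an estimated step of a 10-fold higher number from compound 1 to compound 4 (1.00 log units; beyond the scatter).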

Compound 4, effective concentration (reported as EC, without a stated level of effect): 1000 nM
For compound 4 the middle estimate is 100-fold (2.00 log units) below the measured one, outside the stated range (above it).
By their numbers in this assay, from the lowest: compound 1; then compound 2; then compounds 3 and 4 (each within the scatter of the next).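

In this assay, the end of the molecule that had stayed fixed proves just as sensitive as the sulfonyl end: pyridin-3-yl in place of 2-methylphenyl on the carbonyl carbon gives a 1000-fold higher number from compound 1 to compound 4 (3.00 log units; beyond the scatter), a step of the same size as the largest one seen on the sulfonyl sulfur, a 1000-fold higher number from compound 1 to compound 3 (3.00 log units; beyond the scatter). Keeping the 4-chlorophenyl on the sulfonyl sulfur is therefore not enough to hold the low number of compound 1, which depends on the group at the carbonyl end as well. Nothing available explains why this swap has so large an effect on the read-out.

The step also combines two changes, the loss of the methyl and the entry of a ring nitrogen, so the compounds shown cannot say which of them matters, and a plain phenyl on the carbonyl carbon would help to separate the two. Also open, as far as these compounds go, is how a non-aromatic group such as cyclohexyl, or a longer chain, would fare on that carbonyl carbon.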